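Tert-Butyl Replacing Cyclopropylmethyl at the Hydroxyacyl Carbon

The compounds below may be only part of what the source reports. "The series", "measured", "known", "first", "only" and "open" are said of these compounds alone.

Measured compounds:
compound 1, `O=C(NCc1cc(Cl)ccc1-n1cnnn1)[C@@H]1[C@H]2C[C@H]2CN1C(=O)[C@H](O)CC1CC1`, 1400 nM
compound 2, `CC1(C[C@@H](O)C(=O)N2C[C@H]3C[C@H]3[C@H]2C(=O)NCc2cc(Cl)ccc2-n2cnnn2)CC1`, 500 nM
compound 3, `O=C(NCc1cc(Cl)ccc1-n1cnnn1)[C@@H]1C[C@@H]2C[C@@H]2N1C(=O)[C@H](O)c1cccc(Cl)c1`, 1000 nM

The three compounds share one core and differ only in the group that sits on the hydroxy-bearing carbon of the acyl side chain. In a functional assay on a cell-free system (plasma, Homo sapiens), with a stated time of 3 min (a lower number here means a stronger inhibitor, a higher number a weaker inhibitor), compound 1 gives 1400 nM, the highest number of the three. Its gap to compound 3 lies within the usual scatter of this assay, so the two are not told apart; its gap to compound 2 lies beyond the scatter, and compound 2 shows the lower number.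

Compound 4, `CC(C)(C)[C@@H](O)C(=O)N1C[C@@H]2C[C@@H]2[C@H]1C(=O)NCc1cc(Cl)ccc1-n1cnnn1`, has not yet been measured. It differs from compound 1 in one place: tert-butyl in place of cyclopropylmethyl on a saturated chain carbon bound to a carbonyl carbon and an oxygen on a saturated carbon. The carbon count stays the same; the three-membered ring is gone and a branched chain stands in its place. Going by the values given here, no measured pair in this set isolates this same exchange, so the step can only be guessed at from the spread of the numbers at hand.

Compound 4 is expected to give an estimate of 1000 nM in this assay, with a range from 350 nM to 3000 nM. That estimate corresponds to an expected step of a 1.4-fold lower number from compound 1 to compound 4 (0.15 log units; within the scatter), a change no larger than the scatter.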

Compound 4, half-maximal inhibitory concentration: 570 nM
Compound 4: middle estimate off by 1.8-fold (0.24 log units), on the high side; measured number inside the range.
By their numbers in this assay, from the lowest: compounds 2, 4, 3 and 1 (each within the scatter of the next, the first and the last beyond it).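

In this assay, tert-butyl in place of cyclopropylmethyl on a saturated chain carbon bound to a carbonyl carbon and an oxygen on a saturated carbon gives a 2.5-fold lower number from compound 1 to compound 4 (0.39 log units; beyond the scatter), the first single-place step read at this position. Both groups hold 4 heavy atoms, all carbon, and neither adds a hydrogen-bond donor or acceptor, so this position registers a modest change beyond the scatter when a three-membered ring gives way to a branched chain of equal count. Nothing given here accounts for this step.

The compounds shown leave open whether an oxygen-bearing group such as methoxymethyl, or an amine such as aminomethyl, would be tolerated at this carbon. They also leave open whether a longer branched chain such as neopentyl would carry the step further.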